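This account rests on a few compounds, and the source may have more. Where it says the series, first, only, none or still open, it means among the compounds named here.

Compound 1 `CCCCCCCCc1ccc(CCC(N)(CO)C(=O)O)cc1` was tested in a functional assay on the whole organism (spleen, spleen) with Rattus norvegicus as the target; on this read-out lower numbers stand for an effect already at smaller amounts and higher numbers for an effect only at larger amounts of compound. In this test compound 1 gives > 10 mg/kg, which is a limit of the assay rather than a number, so compound 1 sits at the limit of > 10 mg/kg in this assay, at which 1 of the 2 values shown sits. Compound 2 `CCCCCCCOc1ccc(CC[C@@](N)(CO)CCC)cc1` gives 4.4 mg/kg in this assay. Compound 3 `CCCCCCCCc1ccc(CCC(N)(CO)CCCO)cc1` has not yet been measured; it differs from compound 1 by 3-hydroxypropyl in place of carboxy on a saturated chain carbon bound to an amine nitrogen and two saturated chain carbons. The step of an at least 2.0-fold lower number from compound 1 to compound 3 (0.30 log units; that floor lies within the scatter) is expected to move toward smaller doses, beyond the usual scatter. For compound 3 the estimate is 5 mg/kg, with a range from 1.5 mg/kg to 15 mg/kg.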

Compound 3, dose for 50% inhibition: 0.021 mg/kg
Beside the measured number, compound 3's estimate is 240-fold (2.38 log units) above it; the measured number lies below the stated range.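

At this position, on a saturated chain carbon bound to an amine nitrogen and two saturated chain carbons, the carboxy group is not needed for an effect in this assay: 3-hydroxypropyl in its place gives an at least 470-fold lower number from compound 1 to compound 3 (2.67 log units; beyond the scatter). This size is only a floor, because the value of compound 1 is a limit of the assay and not a number: the limit of > 10 mg/kg in this assay, at which 1 of the 3 values shown sits.

The compounds shown do not separate the loss of the carboxy from the gain of the 3-hydroxypropyl. Going by these compounds, how a longer hydroxyalkyl chain, an amide or a methyl ester would read at this position remains open.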